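The compounds below may be only part of what the source reports. "The series", "measured", "known", "first", "only" and "open" are said of these compounds alone.

In a functional assay on MCF7 cells (Homo sapiens) for inhibition, read by sulforhodamine B assay (on this read-out lower numbers stand for stronger inhibition of growth and higher numbers for weaker inhibition of growth), compound 1 `c1ccc(-c2ccc(-c3ccc(-c4nc5ccccc5[nH]4)cc3)cc2)cc1` gives 39200 nM and compound 2 `Oc1ccc(-c2ccc(-c3ccc(-c4nc5ccccc5[nH]4)cc3)cc2)cc1` gives 30500 nM, while compound 3 `Cc1ccc2[nH]c(-c3ccc(-c4ccc(-c5ccccc5)cc4)cc3)nc2c1` gives 31600 nM and so sits within the scatter of both. Compound 4 `Cc1ccc2[nH]c(-c3ccc(-c4ccc(-c5ccc(O)cc5)cc4)cc3)nc2c1` carries one change from compound 3, phenyl to 4-hydroxyphenyl (hydroxy in place of hydrogen on an aromatic carbon). The same hydroxy in place of hydrogen has one measured precedent, a 1.3-fold lower number from compound 1 to compound 2 (0.11 log units; within the scatter) in this read-out. The methyl that compound 3 already carries came with a 1.2-fold lower number from compound 1 to compound 3 (0.09 log units; within the scatter) on its own. Neither step suggests a real shift, so no step beyond the scatter is expected in this assay. The expected change is a 1.3-fold lower number from compound 3 to compound 4 (0.10 log units; within the scatter) on this reasoning. Compound 4 is estimated at 25000 nM with a likely range from 14000 nM to 43000 nM in this read-out.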

Compound 4, concentration for 50% growth inhibition: 12100 nM
Estimate against measurement, compound 4: 2.1-fold (0.32 log units) above, outside the stated range (below it).
By their numbers in this assay, from the lowest: compound 4; then compounds 2, 3 and 1 (each within the scatter of the next).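

In this assay, hydroxy in place of hydrogen now gives a modest step beyond the scatter, a 2.6-fold lower number from compound 3 to compound 4 (0.42 log units; beyond the scatter), and methyl in place of hydrogen does the same, a 2.5-fold lower number from compound 2 to compound 4 (0.40 log units; beyond the scatter). Together the two groups thus reach what neither reached alone on the core of compound 1, yet the hydroxy change cannot be said to act differently on the two cores: the same change on two cores in this assay, a 1.3-fold lower number (0.11 log units; within the scatter) from compound 1 to compound 2 and a 2.6-fold lower number (0.42 log units; beyond the scatter) from compound 3 to compound 4, 2.0-fold (0.31 log units) apart, within the scatter of two such steps. The methyl change reads the same way: the same change on two cores in this assay, a 1.2-fold lower number (0.09 log units; within the scatter) from compound 1 to compound 3 and a 2.5-fold lower number (0.40 log units; beyond the scatter) from compound 2 to compound 4, 2.0-fold (0.31 log units) apart, within the scatter of two such steps.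

Open, as far as these compounds go, is whether an amine or a carboxylic acid in place of the hydroxy would give a step of similar size, and whether the hydroxy would keep its step elsewhere on that ring.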